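Sulfonamide-diamine series: benzylamine aryl swap in compound 4

This account rests on a few compounds, and the source may have more. Where it says the series, first, only, none or still open, it means among the compounds named here.

Measured so far:
compound 1 `O=S(=O)(NCCCNCc1ccc(Cl)c(C(F)(F)F)c1)c1cc(C(F)(F)F)cc(C(F)(F)F)c1` — 7400 nM
compound 2 `COc1ccc(S(=O)(=O)NCCCCCCNCc2ccc(Br)cc2)cc1` — 13000 nM
compound 3 `CC(C)c1ccc(S(=O)(=O)NCCCCCCNCc2ccc(Br)cc2)cc1` — 5730 nM

In a functional assay on MIA PaCa-2 cells (Homo sapiens) for inhibition, read by MTT assay, with a stated time of 72 h (on this read-out lower numbers stand for stronger inhibition of growth and higher numbers for weaker inhibition of growth), compound 1 gives 7400 nM, the second highest of the three numbers. Its nearest neighbour is compound 3, whose value in this assay is 5730 nM, within the scatter of compound 1; compound 2, at 13000 nM, is the furthest but still within the scatter of compound 1. Among the compounds with values here, the one step that is beyond the scatter is a 2.3-fold lower number from compound 2 to compound 3 (0.36 log units; beyond the scatter), a change of isopropyl in place of methoxy on an aromatic carbon.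

Compound 4 `COc1cccc(CNCCCNS(=O)(=O)c2cc(C(F)(F)F)cc(C(F)(F)F)c2)c1` differs from compound 1 as follows: 3-methoxyphenyl in place of 4-chloro-3-(trifluoromethyl)phenyl on a saturated chain carbon bound to an amine nitrogen. Within the data shown here, no measured pair touches the group on a saturated chain carbon bound to an amine nitrogen, so the only guide is indirect: in the step from compound 2 to compound 3 a methoxy on an aromatic carbon sits with the higher number, and compound 4 brings in a methoxy while the halogen-bearing ring leaves. On this thin basis a modest rise in the number, toward weaker inhibition of growth, is expected for compound 4, with wide uncertainty, a 2.0-fold higher number from compound 1 to compound 4 (0.31 log units; beyond the scatter). Compound 4 is therefore estimated at 15000 nM in this assay, within the range 5000 nM to 45000 nM.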

Compound 4, concentration for 50% growth inhibition: 3400 nM
Beside the measured number, compound 4's estimate is 4.4-fold (0.64 log units) above it; measured number outside the range, below it.
By their numbers in this assay, from the lowest: compounds 4, 3, 1 and 2 (each within the scatter of the next, the first and the last beyond it).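

In this assay, within the data shown here, the group on a saturated chain carbon bound to an amine nitrogen proves responsive to change: 3-methoxyphenyl in place of 4-chloro-3-(trifluoromethyl)phenyl gives a 2.2-fold lower number from compound 1 to compound 4 (0.34 log units; beyond the scatter), toward stronger inhibition of growth, and this is the first step read at this place. A methoxy therefore sits with the lower number here, whereas it sits with the higher number in a 2.3-fold lower number from compound 2 to compound 3 (0.36 log units; beyond the scatter), so no single direction for methoxy holds across these two places in the series, and the step at this place also removes chlorine and trifluoromethyl and goes from 11 heavy atoms to 8. Nothing available here bears on why the number falls at this place.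

Still open, on these data alone, is whether the lower number follows from the arrival of the methoxy or from the departure of the chlorine and trifluoromethyl, a question that an unsubstituted phenyl at the same place would help to separate. Also open, as far as these compounds go, is how far this place tolerates a pyridine ring, or whether the same swap holds with a longer chain in the core of compound 1.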